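A few compounds are considered here, and "the series" means these few. Any claim that something is new, unique, unknown or untested is made for them only; others in the source may bear on it.

Working notes on the series. Compound 1 `CC(C)N(C(=O)CN1C=CN(c2ccccc2)C(=O)C(Cc2n[nH]c3cc(F)ccc23)C1=O)c1ccc(F)cc1` gives, in a functional assay on CHO cells for agonist activity at Melanocyte-stimulating hormone receptor (Homo sapiens), read by a luciferase reporter, with a stated time of 4 h (a higher number here means that more compound is needed for the effect, a lower number that less compound is needed), a value of 14.1 nM. Compound 2 `CC(C)N(C(=O)CN1C=CN(c2ccccc2)C(=O)[C@H](Cc2n[nH]c3cc(F)ccc23)C1=O)c1ccccc1` gives, in this assay, a value of 35.5 nM and so stands with the higher of the two numbers, its gap to compound 1 being beyond the scatter. Compound 3 `CC(C)N(C(=O)CN1C=CN(c2ccccc2)C(=O)C(Cc2n[nH]c3cc(F)ccc23)C1=O)c1ccccc1` is not yet measured. It differs from compound 2 as follows: the two compounds have the same atoms and bonds; at least one stereo element is drawn with a configuration in one of them and without one in the other: 1 of 1 stereo elements differ; a stereocentre at a saturated ring carbon is drawn R in compound 2 and without a configuration in compound 3. For the measured compounds named here, no step between measured compounds is available as a guide. A small upward step in this assay is expected, a 1.4-fold higher number from compound 2 to compound 3 (0.15 log units; within the scatter), since compound 2 carries the drawn configuration. Compound 3 is estimated at 50 nM, within 18 nM to 140 nM.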

Compound 3, half-maximal effective concentration: 186 nM
Compound 3: middle estimate off by 3.7-fold (0.57 log units), on the low side, and the stated range ends below it.
By their numbers in this assay, from the lowest: compound 1; then compound 2; then compound 3.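

In this assay, a change confined to the saturated ring carbon, drawn R in compound 2 and without a configuration in compound 3, comes with a 5.2-fold higher number from compound 2 to compound 3 (0.72 log units; beyond the scatter), so the drawing of this centre alone separates the two numbers beyond the scatter. For the compounds shown here, the only difference behind that step is stereochemical: the fact that one of compounds 2 and 3 is drawn with a defined configuration and the other without, at the place where they differ Among the compounds without a drawn configuration, hydrogen in place of fluoro on an aromatic carbon gives a 13-fold higher number from compound 1 to compound 3 (1.12 log units; beyond the scatter), the larger step of the two.

Open, going by these compounds, is how the S configuration at the ring carbon reads, and whether fluoro and the R configuration together go further. Also open, on these data alone, is how chloro or methoxy reads in place of that fluoro.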